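A few compounds are considered here, and "the series" means these few. Any claim that something is new, unique, unknown or untested is made for them only; others in the source may bear on it.

Measured compounds in a functional assay on MCF7 cells (Homo sapiens) for cytotoxicity, read by MTT assay, with a stated time of 48 h; a lower number here means a stronger inhibitor, a higher number a weaker inhibitor:

Compound 1 `COc1ccc(-c2ccnc(Nc3ccc4c(c3)c(/C=C3/C(=O)Nc5ccccc53)cn4C)n2)cc1`. In this assay compound 1 gives only a limit, > 100000 nM.
Compound 2 `Cn1cc(/C=C2/C(=O)Nc3ccccc32)c2cc(Nc3nccc(-c4ccc(Cl)cc4)n3)ccc21`. In this assay compound 2 gives 23500 nM.

Among the compounds with values here, compound 2 stands as the only compound with a number in this assay; the other value shown is a limit, (the limit of > 100000 nM in this assay, at which 1 of the 2 values shown sits), so nothing can be said about how far apart the two compounds really lie. Within the data shown here, the step from compound 1 to compound 2, chloro in place of methoxy on an aromatic carbon, gave an at least 4.2-fold lower number from compound 1 to compound 2 (0.62 log units; beyond the scatter), and this is the sole measured step.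

Compound 3 `Cn1cc(/C=C2/C(=O)Nc3ccccc32)c2cc(Nc3nccc(-c4ccc(C(F)(F)F)cc4)n3)ccc21` is not yet measured. It differs from compound 2 in one place: trifluoromethyl in place of chloro on an aromatic carbon. Among the measured compounds shown here, no measured step changes chloro for trifluoromethyl, and the one step known involves a limit, so the expected size for compound 3 rests on thin ground. Compound 3 is estimated to lie close to compound 2, and the step from compound 2 to compound 3 is expected to be a 1.3-fold lower number from compound 2 to compound 3 (0.12 log units; within the scatter), within the scatter. The estimate for compound 3 is 18000 nM, between 5000 nM and 60000 nM.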

Compound 3, half-maximal inhibitory concentration: 65200 nM
The estimate for compound 3 lay 3.6-fold (0.56 log units) below the measured number; measured number above the stated range.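

In this assay, trifluoromethyl in place of chloro on this aromatic carbon, para to a large group, gave a 2.8-fold higher number from compound 2 to compound 3 (0.44 log units; beyond the scatter). Within the data shown here, this is the first step at the position read between two actual numbers, and it places the 4-chlorophenyl compound ahead of the 4-(trifluoromethyl)phenyl compound, so leaving methoxy does not by itself settle the outcome, as the earlier step alone might have suggested. Trifluoromethyl in place of methoxy gave an at least 1.5-fold lower number from compound 1 to compound 3 (0.18 log units; that floor lies within the scatter), and since that floor lies within the scatter and compound 1 has only a limit, this step cannot be read as showing a real difference: the limit of > 100000 nM in this assay, at which 1 of the 3 values shown sits.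

From the compounds shown here alone, whether fluoro, an amine or a carboxylic acid at this position would give a lower number than compound 2 stays open, as does whether the order of chloro and trifluoromethyl would hold at another place on the same ring. The compounds shown also leave open how changes elsewhere in the shared core would act, since all three differ only in this one group.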